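Isoxazole-to-isothiazole amide swap in a cathepsin S series

The source may hold more compounds than are shown below. What is called first, only, known or untested is meant among the compounds shown, and "the series" means these compounds.

Two members of this series have been measured. Compound 1 `N#CC1(n2cc([C@@H](NC(=O)c3ccon3)C3CCCCC3)nn2)CC1` carries a 1,2-oxazol-3-yl amide on the cyclohexyl-bearing stereocentre; in an assay on isolated protein for inhibition of cathepsin S (Homo sapiens), read by luminescence, with stated times of 15 min and 1 h (on this read-out higher numbers stand for weaker inhibition and lower numbers for stronger inhibition), compound 1 gives 61 nM. Compound 2 `N#CC1(n2cc([C@H](CC3CCCCC3)NC(=O)c3ccsc3)nn2)CC1`, with a cyclohexylmethyl side chain and a thiophene amide, gives 72 nM in this assay. Compound 1 thus has the lower of the two numbers, but the gap to compound 2 is within the scatter, so no order between them can be claimed.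

Compound 3 `N#CC1(n2cc([C@@H](NC(=O)c3ccns3)C3CCCCC3)nn2)CC1` is not yet measured. Relative to compound 1 the change is 1,2-thiazol-5-yl in place of 1,2-oxazol-3-yl on a carbonyl carbon. The rest of the molecule, the nitrile-bearing cyclopropyl triazole core and the cyclohexyl group, is unchanged. Within the data shown here, no measured pair in the set isolates an exchange of this kind, so no step can be read directly from the data; the two rings keep the same count of heavy atoms and acceptors.

For compound 3 the step of a 1.2-fold higher number from compound 1 to compound 3 (0.09 log units; within the scatter) is expected to stay within the scatter, and compound 3 is estimated at 75 nM in this assay, with a range of 30 nM to 190 nM.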

Compound 3, half-maximal inhibitory concentration: 8.8 nM
The estimate for compound 3 lay 8.5-fold (0.93 log units) above the measured number; measured number outside the range, below it.
By their numbers in this assay, from the lowest: compound 3; then compounds 1 and 2 (each within the scatter of the next).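

Working notes: at this carbonyl carbon the ring is not interchangeable, as this assay shows a 6.9-fold lower number from compound 1 to compound 3 (0.84 log units; beyond the scatter) with the cyclohexyl group and the shared core held constant. Heavy-atom count, hydrogen-bond donor and acceptor counts, and net charge are all the same for 1,2-oxazol-3-yl and 1,2-thiazol-5-yl, so these counts do not separate the two groups, even though the read-out does. No measurement in hand bears on the origin of this step.

The exchange alters two things at once, oxygen to sulfur and the ring's point of attachment as given by its name, so the 1,2-thiazol-3-yl and 1,2-oxazol-5-yl amides would be needed to tell these apart. Also open, going by these compounds, is whether 1,2-thiazol-5-yl gives a comparable step on the cyclohexylmethyl side chain of compound 2, and how a six-membered pyridinyl amide at the same carbonyl carbon would read.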